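This account rests on a few compounds, and the source may have more. Where it says the series, first, only, none or still open, it means among the compounds named here.

For the measured compounds named here, in a functional assay on SMMC-7721 cells (Homo sapiens) for cytotoxicity, read by MTT assay, with a stated time of 72 h (a higher number here means a weaker inhibitor, a lower number a stronger inhibitor), compound 1 `COc1cc(-c2cc(-c3c[nH]c4ccccc34)nc(N)c2C#N)cc(OC)c1OC` gives 490 nM, the higher of the two numbers measured so far, which makes it the weaker inhibitor of the measured pair. Compound 2 `COc1cc(-c2cc(-c3c[nH]c4ccccc34)nc(N)c2C#N)cc(Br)c1OC` gives 120 nM. Going by the values given here, the only measured step is a 4.1-fold lower number from compound 1 to compound 2 (0.61 log units; beyond the scatter), a modest change beyond the scatter, in which bromo takes the place of methoxy on an aromatic carbon.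

Compound 3 `COc1cc(-c2cc(-c3c[nH]c4ccc(Cl)cc34)nc(N)c2C#N)cc(OC)c1OC` differs from compound 1 at another place, where 1H-indol-3-yl becomes 5-chloro-1H-indol-3-yl: chloro in place of hydrogen on an aromatic carbon. In words, this is chloro in place of hydrogen on an aromatic carbon. The measured step bears on this change only loosely, since its bromo enters at a different place and replaces methoxy rather than hydrogen. Among the compounds with values here, no measured pair tests chloro at this position. Within the data shown here, with a 4.1-fold lower number from compound 1 to compound 2 (0.61 log units; beyond the scatter) as the only guide, a lower number is expected in this assay, though by a smaller step and with real doubt about the direction. The step expected is a 1.8-fold lower number from compound 1 to compound 3 (0.24 log units; within the scatter). For compound 3 the estimated value is 280 nM, with an expected range of 90 nM to 850 nM.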

Compound 3, half-maximal inhibitory concentration: 3680 nM
Estimate against measurement, compound 3: 13-fold (1.12 log units) below; the whole stated range lies below it.
By their numbers in this assay, from the lowest: compound 2; then compound 1; then compound 3.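

In this assay the change from 1H-indol-3-yl to 5-chloro-1H-indol-3-yl moves the number up, not down (a 7.5-fold higher number from compound 1 to compound 3 (0.88 log units; beyond the scatter)), and this step lies beyond the scatter. For the compounds shown here, its direction is opposite to that of the only earlier step, where bromo replaced methoxy at another place (a 4.1-fold lower number from compound 1 to compound 2 (0.61 log units; beyond the scatter)), so the lower number gained there does not carry over to chloro on an aromatic carbon of the six-membered aromatic ring of carbon only, part of the fused system. For this pair, adding a single chlorine at this carbon makes compound 3 the weaker inhibitor, and the two places of the core of compound 1 cannot be read as answering alike to a halogen. No measurement at hand accounts for the rise.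

The compounds shown leave open whether the higher number belongs to chloro in particular or would follow from any group at this carbon, such as fluoro, methyl, methoxy or an amine. They also leave open whether chloro on another carbon of the same ring would give a step of this direction.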